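The compounds below may be only part of what the source reports. "The series", "measured", "known", "first", "only" and "open" are said of these compounds alone.

Measured in a functional assay on HeLa cells (Homo sapiens) for inhibition, read by MTT assay, with a stated time of 48 h; a lower number here means a stronger inhibitor, a higher number a weaker inhibitor:
- compound 1 `Oc1cccc(C(c2c[nH]c3ccc(Br)cc23)c2c[nH]c3ccc(Br)cc23)c1`: 3900 nM
- compound 2 `COc1ccc(C(c2c[nH]c3ccc(Br)cc23)c2c[nH]c3ccc(Br)cc23)cc1`: 5500 nM
- compound 3 `COc1ccc(C(c2c[nH]c3ccc(Br)cc23)c2c[nH]c3ccc(Br)cc23)c(OC)c1`: 63200 nM

Compound 3 has the highest number of the three, which makes it the weakest inhibitor here. The unmeasured compound 4 `COc1ccc(C(c2c[nH]c3ccc(Br)cc23)c2c[nH]c3ccc(Br)cc23)cc1OC` differs from it in one place: 3,4-dimethoxyphenyl in place of 2,4-dimethoxyphenyl on a saturated chain carbon bound to two aromatic carbons. This puts 3,4-dimethoxyphenyl in place of 2,4-dimethoxyphenyl on a saturated chain carbon bound to two aromatic carbons, with the same atoms joined differently.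

The closest evidence is an 11-fold higher number from compound 2 to compound 3 (1.06 log units; beyond the scatter), a large rise on adding a methoxy. The large 16-fold higher number from compound 1 to compound 3 (1.21 log units; beyond the scatter) agrees, whereas a 1.4-fold higher number from compound 1 to compound 2 (0.15 log units; within the scatter) shows that a change of aryl group need not matter. Among the measured compounds shown here, no measured compound carries the 3,4-dimethoxyphenyl group, so it is open whether the rise follows any added methoxy or only the 2,4-dimethoxyphenyl arrangement. A partial return towards compound 2 at 5500 nM therefore seems likeliest. The expected change is a 5.3-fold lower number from compound 3 to compound 4 (0.72 log units; beyond the scatter). Compound 4 is estimated at 12000 nM, with an expected range from 3500 nM to 45000 nM.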

Compound 4, half-maximal inhibitory concentration: 6100 nM
Beside the measured number, compound 4's estimate is 2.0-fold (0.29 log units) above it; measured number inside the range.
By their numbers in this assay, from the lowest: compounds 1, 2 and 4 (each within the scatter of the next); then compound 3.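

Moving one methoxy, with the same atoms joined differently, gives a 10-fold lower number from compound 3 to compound 4 (1.02 log units; beyond the scatter) in this assay and so shows that the large rise at compound 3 does not follow from having two methoxy groups on this aryl ring as such. Adding a methoxy on an aromatic carbon can give a 1.1-fold higher number from compound 2 to compound 4 (0.04 log units; within the scatter) or an 11-fold higher number from compound 2 to compound 3 (1.06 log units; beyond the scatter) and so the same addition has very different outcomes, depending on where it is placed. With a 1.6-fold higher number from compound 1 to compound 4 (0.19 log units; within the scatter) as well, compound 4 cannot be told apart from compound 1 or compound 2, and among these four compounds only the 2,4-dimethoxyphenyl group stands out.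

No measurement shown here explains why this one arrangement differs. Going by these compounds, it also remains open whether a single 2-methoxyphenyl group would bring the same rise, and how an amine or a carboxylic acid on this ring would behave.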